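The compounds below may be only part of what the source reports. "The series", "measured", "known", "first", "only" and "open" are said of these compounds alone.

Going by the values given here, in a functional assay on DU-145 cells (Homo sapiens) for cytotoxicity, read by MTT assay, with a stated time of 72 h (on this read-out lower numbers stand for stronger inhibition of growth and higher numbers for weaker inhibition of growth), compound 1 (`N#C/C(=C/c1ccc(Cl)cc1)C(=O)c1ccc[nH]1`) gives 32000 nM, the only exact number so far. For compound 2 (`N#C/C(=C/c1ccc(Cl)c(Cl)c1)C(=O)c1ccc[nH]1`) the reading is < 10000 nM, which is a limit of the assay. Compound 3 (`N#C/C(=C/c1ccc(O)cc1)C(=O)c1ccc[nH]1`) differs from compound 1 by hydroxy in place of chloro on an aromatic carbon. Among the compounds with values here, the one measured step, an at least 3.2-fold lower number from compound 1 to compound 2 (0.50 log units; beyond the scatter), bears on this only loosely: chloro is added there, not replaced. Going by that step, a modest shift toward higher numbers in this assay is expected. The estimated step is a 1.4-fold higher number from compound 1 to compound 3 (0.15 log units; within the scatter). Compound 3 is expected at 45000 nM, with an estimated range of 12000 nM to 150000 nM.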

Compound 3, concentration for 50% growth inhibition: < 10000 nM
Compound 3: only a limit was reported; the forecaster's own chance of this, stated with the estimate: 25%; at least 4.5-fold (0.65 log units) between middle value and limit.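

At this place, on an aromatic carbon para to a large group, hydroxy in place of chloro gives an at least 3.2-fold lower number from compound 1 to compound 3 (0.50 log units; beyond the scatter) in this assay. The chloro of compound 1 is therefore not needed here for stronger growth inhibition, whereas the earlier step showed only a chloro being added. The reading of compound 3 is a limit, so the full size of this step stays unknown: the limit of < 10000 nM in this assay, at which 2 of the 3 values shown sit.

Still open, from the compounds shown here alone, is how far compound 3 lies beyond its limit. Also open, going by these compounds, is whether an amine or a methoxy group at this place would match hydroxy.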